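Compound 3 after two compounds at the limit

The source may hold more compounds than are shown below. What is called first, only, known or untested is meant among the compounds shown, and "the series" means these compounds.

Measured in a functional assay on NALM-6 cells (Homo sapiens) for cytotoxicity, with a stated time of 72 h; on this read-out higher numbers stand for an effect only at larger amounts of compound and lower numbers for an effect already at smaller amounts:
Compound 1 `COc1ccc(/C=C/[C@@](C)(/C=C/c2ccc(O)cc2)CCC=C(C)C)cc1`: > 43400 nM
Compound 2 `CC(C)=CCC[C@](C)(/C=C/c1ccc(O)cc1)/C=C/c1ccc(C#N)cc1`: > 43400 nM

Neither entry is a number. Each is a limit of the assay. Compound 2 stands at the limit of > 43400 nM in this assay, at which 2 of the 2 values shown sit. Going by the values given here, the one measured step is a step that the two limits leave unreadable from compound 1 to compound 2. It touched the ring that changes next, but it offers no size to carry forward.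

Compound 3 `CC(C)=CCC[C@](C)(/C=C/c1ccc(O)cc1)/C=C/c1cccc(F)c1` has not been measured yet. Its difference from compound 2 is 3-fluorophenyl in place of 4-cyanophenyl on a double-bonded chain carbon bound to a double-bonded chain carbon. In words, 3-fluorophenyl takes the place of 4-cyanophenyl.

With no readable step to draw on, no shift beyond the scatter is expected in this assay, and no direction can be named. The expected step is a number no higher from compound 2 to compound 3 (the limit leaves the size open). A report of only a limit is the likeliest outcome. For compound 3 the estimate is 43400 nM, with an expected range from 15000 nM to 90000 nM.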

Compound 3, half-maximal effective concentration: > 43400 nM
Compound 3 gave a limit, no number (the forecaster's own chance of this, stated with the estimate: 75%); the middle value lies on the limit itself.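

Going by these compounds alone, compound 1, compound 2 and compound 3 each gave only a limit in this assay, not a number, and no step among them can be read. The compounds shown leave open whether swapping these aromatic groups changes the read-out, and at what concentration any of them would act.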